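Aminophenyl enone benzoxaboroles: moving the amino group on compound 3

The source may hold more compounds than are shown below. What is called first, only, known or untested is meant among the compounds shown, and "the series" means these compounds.

Compound 1 `O=C(/C=C/c1ccc2c(c1)B(O)OC2)c1ccccc1` gives 15900 nM in a toxicity assay on MCF-10A cells (Homo sapiens) for cytotoxicity, read by MTT assay, with a stated time of 48 h; on this read-out higher numbers stand for weaker inhibition and lower numbers for stronger inhibition; compound 2 `Cc1ccc(C(=O)/C=C/c2ccc3c(c2)B(O)OC3)cc1` gives 8300 nM and compound 3 `Nc1ccc(C(=O)/C=C/c2ccc3c(c2)B(O)OC3)cc1` gives 19900 nM. Compound 3 carries the highest number of the three: a 1.3-fold higher number from compound 1 to compound 3 (0.10 log units; within the scatter), while a 2.4-fold higher number from compound 2 to compound 3 (0.38 log units; beyond the scatter). Compound 4 `Nc1cccc(C(=O)/C=C/c2ccc3c(c2)B(O)OC3)c1` differs from compound 3 by 3-aminophenyl in place of 4-aminophenyl on a carbonyl carbon. Among the compounds with values here, no measured step shifts the amino group itself; the nearest comparisons exchange the substituent on the same aromatic carbon, a 1.9-fold lower number from compound 1 to compound 2 (0.28 log units; within the scatter) and a 1.3-fold higher number from compound 1 to compound 3 (0.10 log units; within the scatter), and both are small. These bear only indirectly on the change, so in this assay a step within the scatter is expected, a 1.1-fold lower number from compound 3 to compound 4 (0.04 log units; within the scatter). Compound 4 is estimated at 18000 nM, with a range from 8000 nM to 40000 nM.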

Compound 4, half-maximal inhibitory concentration: 19600 nM
Compound 4: the middle estimate sits 1.1-fold (0.04 log units) below what was measured; the range from low to high includes it.
By their numbers in this assay, from the lowest: compounds 2, 1, 4 and 3 (each within the scatter of the next, the first and the last beyond it).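

In this assay, within the data shown here, moving the amino group gives the first direct reading at this position, and 3-aminophenyl and 4-aminophenyl on the carbonyl carbon cannot be told apart (a 1.0-fold lower number from compound 3 to compound 4 (0.01 log units; within the scatter)). The new isomer also remains within the scatter of the unsubstituted compound (a 1.2-fold higher number from compound 1 to compound 4 (0.09 log units; within the scatter)), while the modest gap to the methyl compound recurs with 3-aminophenyl in place of 4-methylphenyl (a 2.4-fold higher number from compound 2 to compound 4 (0.37 log units; beyond the scatter)). No evidence on the cause is available. Still open, going by these compounds, is whether a dimethylamino group or a carboxylic acid in place of the amino group would shift the number beyond the scatter.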